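Replacing the Isopentyl Chain with a Fluorobenzyl Group

A few compounds are considered here, and "the series" means these few. Any claim that something is new, unique, unknown or untested is made for them only; others in the source may bear on it.

Compound 1 `CC(C)CCN1C(=O)C(C2=NS(=O)(=O)c3cc(NS(C)(=O)=O)ccc3N2)=C(O)C2CCCC21` gives 0.167 h in an in vitro ADME assay on microsomes from liver (Homo sapiens) for metabolic stability (a lower number here means that the compound disappears faster, a higher number that the compound lasts longer), the lowest of the two numbers shown, with compound 2 as its nearest neighbour. Compound 2 `CC(C)CCN1C(=O)C(C2=NS(=O)(=O)c3cc(NS(C)(=O)=O)ccc3N2)=C(O)[C@H]2CCC[C@H]21` gives 0.383 h in this assay. The step of a 2.3-fold higher number from compound 1 to compound 2 (0.36 log units; beyond the scatter) coincides with the fact that one of compounds 1 and 2 is drawn with a defined configuration and the other without, at the place where they differ, which is the only distinction between the two. Compound 3 `CS(=O)(=O)Nc1ccc2c(c1)S(=O)(=O)N=C(C1=C(O)[C@H]3CCCC[C@H]3N(Cc3ccc(F)cc3)C1=O)N2` reaches only the limit of this assay, reported as > 1 h, so no number is known for it.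

Compound 4 `CS(=O)(=O)Nc1ccc2c(c1)S(=O)(=O)N=C(C1=C(O)C3CCCC3N(Cc3cccc(F)c3)C1=O)N2` differs from compound 1 by 3-fluorophenyl in place of isobutyl on a saturated chain carbon bound to an amide-type nitrogen in a ring. Going by the values given here, no measured pair isolates this change. Compound 3 also carries a fluorobenzyl group, and its value sits at the limit of > 1 h in this assay, at which 1 of the 3 values shown sits, but it differs from compound 1 in more than one place, so it offers only a loose hint that benzyl-bearing analogues may last longer. A modest rise is therefore expected for compound 4, as the step of a 3.0-fold higher number from compound 1 to compound 4 (0.48 log units; beyond the scatter). Compound 4 is estimated at 0.5 h, within a range from 0.15 h to 1.5 h.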

Compound 4, half-life: 0.85 h
Beside the measured number, compound 4's estimate is 1.7-fold (0.23 log units) below it; measured number inside the range.
By their numbers in this assay, from the lowest: compound 1; then compound 2; then compound 4. At a limit, above all of these: compound 3.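

In this assay, putting 3-fluorophenyl in place of isobutyl on a saturated chain carbon bound to an amide-type nitrogen in a ring gives a 5.1-fold higher number from compound 1 to compound 4 (0.71 log units; beyond the scatter). Going by these compounds alone, this is the first measured pair to isolate a change at this position, and it shows that the read-out responds to the group carried there, with neither compound drawn with a configuration at the saturated ring carbons. The only earlier step concerned a different kind of difference: the fact that one of compounds 1 and 2 is drawn with a defined configuration and the other without, at the place where they differ

From the compounds shown here alone, whether this step belongs to the aromatic ring or to the fluorine stays open, and a plain benzyl group or a cyclohexylmethyl group at this position would help to separate the two. Also open, going by these compounds, is how the 3-fluorobenzyl group behaves with a defined configuration at the saturated ring carbons.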